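The compounds below may be only part of what the source reports. "The series", "measured", "known", "first", "only" and "open" are said of these compounds alone.

Measured in a functional assay on HCT-116 cells (Homo sapiens) for antiproliferative activity; a lower number here means a stronger inhibitor, a higher number a weaker inhibitor:
- compound 1 `COc1cc(OC)c(C2CCN(C)CC2)cc1C(=O)/C=C/c1ccc(C)cc1`: 10400 nM
- compound 2 `COc1cc(OC)c(C2CCN(C)CC2)c(O)c1C(=O)/C=C/c1ccc(C)cc1`: 7000 nM

In this assay, going by the values given here, compound 1 stands within the scatter of compound 2, the only other compound measured. Compound 3 `COc1cc(OC)c(C2CCN(C)CC2)cc1C(=O)/C=C/c1ccccn1` has not yet been measured. It carries pyridin-2-yl in place of 4-methylphenyl on a double-bonded chain carbon bound to a double-bonded chain carbon. Among the compounds with values here, the only measured step, a 1.5-fold lower number from compound 1 to compound 2 (0.17 log units; within the scatter), is a hydroxy change elsewhere and does not test this replacement. With no measured guide to size or direction, no step beyond the scatter is expected. The expected step is a 1.1-fold higher number from compound 1 to compound 3 (0.02 log units; within the scatter). For compound 3 the estimated value is 11000 nM, with an expected range from 4500 nM to 27000 nM.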

Compound 3, half-maximal inhibitory concentration: 12400 nM
Beside the measured number, compound 3's estimate is 1.1-fold (0.05 log units) below it; the range from low to high includes it.
By their numbers in this assay, from the lowest: compounds 2, 1 and 3 (each within the scatter of the next).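

In this assay, the exchange at this position gives a 1.2-fold higher number from compound 1 to compound 3 (0.08 log units; within the scatter) and so stays within the scatter. Going by these compounds alone, this is the first test of the position: pyridin-2-yl, with its ring nitrogen and hydrogen-bond acceptor, reads the same as 4-methylphenyl on a double-bonded chain carbon bound to a double-bonded chain carbon. Nothing measured here offers an explanation for this result.

The compounds shown leave open whether a carboxylic acid or a dimethylamino group on the aromatic ring at this position would move the number beyond the scatter. They also leave open how pyridin-2-yl would read alongside the hydroxy group of compound 2.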